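Acetamido in Place of Cyano: Three Measured, One Pending

This account rests on a few compounds, and the source may have more. Where it says the series, first, only, none or still open, it means among the compounds named here.

Measured compounds in a physicochemical assay for lipophilicity, at pH 7.4; a lower number here means a more polar compound, a higher number a more lipophilic compound:
- compound 1 `Cc1cc(COc2ccccc2C#N)nc(-c2ccccn2)n1` gives 2.7
- compound 2 `Cc1cc(COc2cccc(C#N)c2)nc(-c2ccccn2)n1` gives 2.7
- compound 3 `CC(=O)Nc1ccccc1OCc1cc(C)nc(-c2ccccn2)n1` gives 1.6

Compound 1 and compound 2 share the same atoms joined differently; the difference between the two cores is not broken down here, and in this assay the two stand level at the digits given, within the scatter. From compound 1 to compound 3 the change is acetamido in place of cyano on an aromatic carbon, and this brought a number 1.10 log units lower from compound 1 to compound 3 (beyond the scatter).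

Compound 4 `CC(=O)Nc1cccc(OCc2cc(C)nc(-c3ccccn3)n2)c1` has not yet been measured. It arises from compound 2 by acetamido in place of cyano on an aromatic carbon. This is the same kind of change as that from compound 1 to compound 3, but the place differs: in compound 3 the entering group sits ortho to a large group, in compound 4 meta to a large group.

Among the measured compounds shown here, because the only measured instance of this change is a number 1.10 log units lower from compound 1 to compound 3 (beyond the scatter), a step of similar size is expected, a number 1.10 log units lower from compound 2 to compound 4 (beyond the scatter), with some allowance for the different place. Compound 4 is therefore estimated at 1.6, within 1.2 to 2.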

Compound 4, distribution coefficient: 2.1
Beside the measured number, compound 4's estimate is 0.50 log units below it; the measured number lies above the stated range.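

In this assay the change from cyano to acetamido gave a number 0.60 log units lower from compound 2 to compound 4 (beyond the scatter) and so ran in the same direction as a number 1.10 log units lower from compound 1 to compound 3 (beyond the scatter) but was the smaller of the two steps. Across these two pairs the direction of the change carried from one core to the other, but the size did not, so a step measured on one core cannot be taken over unchanged, and two pairs establish no general rule for the series. With the entering group meta to a large group in compound 4 and differently placed in compound 3, the data do not show whether the place or something else sets the size of the step, and nothing given here accounts for the difference.

The compounds shown leave open how an amine, a carboxylic acid or a longer chain would compare with cyano and acetamido at these places. They also leave open whether either of those groups would give matching steps on the two cores.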